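Swapping a distant aryl group: does the acid dissociation move?

The source may report more compounds than this note shows. Statements on the series, on what has been measured and on what is new or still open speak of the compounds shown alone.

Measured compounds:
Compound 1, `COc1cccc(CNCCCNc2ccnc3cc(-c4ccc(F)cc4)ccc23)c1O`, gives 9.47 in a physicochemical assay for acid dissociation.
Compound 2, `COc1cccc(CNCCCNc2ccnc3cc(Cc4cc(C)cc(C)c4)ccc23)c1O`, gives 9.47 in this assay.

Compound 2 stands level with compound 1 at the digits shown; the step of no change at the digits printed from compound 1 to compound 2 (within the scatter) lies within the scatter of the method. That step replaced a 4-fluorophenyl with a 3,5-dimethylbenzyl on an aromatic carbon of the shared core, far from the basic amine and the phenol, and the read-out did not move.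

Compound 3, `COc1ccc(Oc2ccc3c(NCCCNCc4cccc(OC)c4O)ccnc3c2)cc1`, has not yet been measured. The change from compound 2 is 4-methoxyphenoxy in place of 3,5-dimethylbenzyl on an aromatic carbon. It again touches only the group on that aromatic carbon of the fused ring system and leaves the rest of the shared core untouched.

Within the data shown here, the one step that bears on this, from compound 1 to compound 2, was a null step in this assay. On that basis, no step beyond the scatter is expected in this assay, in either direction. Compound 3 is therefore expected to give about 9.47, within 9.1 to 9.85, meaning an expected step of no change at the digits printed from compound 2 to compound 3 (within the scatter).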

Compound 3, acid dissociation constant: 9.28
Estimate against measurement, compound 3: 0.19 log units above, within the range that was stated.
By their numbers in this assay, from the lowest: compounds 3, 1 and 2 (each within the scatter of the next).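

In this assay, 4-methoxyphenoxy in place of 3,5-dimethylbenzyl gives a number 0.19 log units lower from compound 2 to compound 3 (within the scatter) and, in place of 4-fluorophenyl, gives a number 0.19 log units lower from compound 1 to compound 3 (within the scatter) on the same aromatic carbon. This extends the earlier null result to a group of a different composition: 4-methoxyphenoxy has the same count of heavy atoms as 3,5-dimethylbenzyl, but it brings two oxygen atoms and two hydrogen-bond acceptors where 3,5-dimethylbenzyl has none, and the read-out still stays within the scatter across all three compounds. No accompanying measurement helps to interpret this result, so the numbers alone describe only what was seen at this position.

All three groups shown at this position contain one six-membered aromatic ring of carbon only, so the compounds shown do not say whether an amine, a carboxylic acid or a longer chain on the same carbon would also stay within the scatter. They also leave open whether changing the shared core elsewhere, for example replacing the methoxy group on the phenol ring with a carboxylic acid, would shift the number in this assay.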